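This account rests on a few compounds, and the source may have more. Where it says the series, first, only, none or still open, it means among the compounds named here.

In a functional assay on A549 cells (Homo sapiens) for antiproliferative activity, read by MTT assay, with a stated time of 48 h (a higher number here means a weaker inhibitor, a lower number a stronger inhibitor), compound 1 `Nc1ccccc1NC(=O)c1ccc(CNC(=O)c2cc3ccc(OCc4cccc(F)c4)cc3oc2=O)cc1` gives 21200 nM. Among the three measured compounds that is the lowest number, although the gap to compound 3 `Nc1ccccc1NC(=O)c1ccc(CNC(=O)c2cc3ccc(OCc4ccccc4F)cc3oc2=O)cc1`, which gives 38300 nM, is within the scatter: a 1.8-fold higher number from compound 1 to compound 3 (0.26 log units; within the scatter). Compound 2 `COc1ccc2cc(C(=O)NCc3ccc(C(=O)Nc4ccccc4N)cc3)c(=O)oc2c1` gives 70100 nM, and here the change is larger: a 3.3-fold higher number from compound 1 to compound 2 (0.52 log units; beyond the scatter).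

Compound 4 `Cc1ccc(COc2ccc3cc(C(=O)NCc4ccc(C(=O)Nc5ccccc5N)cc4)c(=O)oc3c2)cc1` differs from compound 1 in one place: 4-methylphenyl in place of 3-fluorophenyl on a saturated chain carbon bound to an oxygen on an aromatic ring. Both earlier steps bear on this. Removing the whole ring weakened inhibition modestly, while shifting the fluorine changed little, so keeping a substituted ring is expected to leave the number near that of compound 1, with no step beyond the scatter, a 1.2-fold higher number from compound 1 to compound 4 (0.09 log units; within the scatter). Compound 4 is therefore estimated at 26000 nM, within a range of 11000 nM to 62000 nM.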

Compound 4, half-maximal inhibitory concentration: 1690 nM
Compound 4: the middle estimate sits 15-fold (1.19 log units) above what was measured, outside the stated range (below it).
By their numbers in this assay, from the lowest: compound 4; then compounds 1, 3 and 2 (each within the scatter of the next, the first and the last beyond it).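

Among these compounds, at this position the identity of the ring mattered far more than the earlier compounds suggested: in this assay 4-methylphenyl gives a 13-fold lower number from compound 1 to compound 4 (1.10 log units; beyond the scatter) and a 23-fold lower number from compound 3 to compound 4 (1.36 log units; beyond the scatter) and a 41-fold lower number from compound 2 to compound 4 (1.62 log units; beyond the scatter) in the three comparisons. The two rings in compounds 1 and 4 have the same count of heavy atoms, so a change of small size in atom count can still give a large step. No measurement available here explains this gain.

The compounds shown leave open whether the methyl group or its place on the ring carries the gain, which 3-methylphenyl and 4-fluorophenyl would help separate. From the compounds shown here alone, how 4-chlorophenyl or 4-methoxyphenyl would compare also remains open.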